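Two sulfur-linked propargylamines and a dichlorophenyl analogue

This account rests on a few compounds, and the source may have more. Where it says the series, first, only, none or still open, it means among the compounds named here.

The two measured compounds share one core and differ in the group hanging from the sulfur. Compound 1 `C#CCNC1CCc2c(SCc3ccc(Br)cc3)cccc21` carries a bromophenyl group on a one-carbon chain, while compound 2 `C#CCNC1CCc2c(SCCc3cccc(Br)c3)cccc21` carries a 3-bromophenyl group on a two-carbon chain. In an assay on isolated protein for inhibition of Amine oxidase [flavin-containing] B (Homo sapiens) (a lower number here means a stronger inhibitor, a higher number a weaker inhibitor), compound 1 gives 1310 nM, and in this assay compound 2 gives 30500 nM, the higher of the two numbers and therefore the weaker inhibitor of the pair, by a margin well beyond the usual scatter.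

Compound 3 `C#CCNC1CCc2c(SCCc3ccc(Cl)c(Cl)c3)cccc21` has not yet been measured. It keeps the two-carbon chain of compound 2 and changes only the aromatic group: 3,4-dichlorophenyl in place of 3-bromophenyl on a saturated chain carbon, two bonds along the chain from a sulfur. For the measured compounds named here, no measured pair shows what swapping one halogen pattern for another does on this chain, so the size of the step is open. A modest move toward a lower number is expected, within or just beyond the scatter, giving an estimated step of a 2.0-fold lower number from compound 2 to compound 3 (0.31 log units; beyond the scatter). On that basis compound 3 is expected to give 15000 nM in this assay, with a likely range from 4000 nM to 50000 nM.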

Compound 3, half-maximal inhibitory concentration: 3850 nM
Compound 3: the middle estimate sits 3.9-fold (0.59 log units) above what was measured; the measured number lies below the stated range.
By their numbers in this assay, from the lowest: compound 1; then compound 3; then compound 2.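

In this assay, putting 3,4-dichlorophenyl in place of 3-bromophenyl on a saturated chain carbon, two bonds along the chain from a sulfur, gives a 7.9-fold lower number from compound 2 to compound 3 (0.90 log units; beyond the scatter). For the compounds shown here, this is the first pair here that differs in one place only, so it shows that the aromatic group alone can move the number well beyond the scatter while the chain and the shared core stay the same. The step comes with no change in the counts of hydrogen-bond donors or acceptors and no net charge on either group, and nothing available here accounts for its size.

The change alters the halogen and the substitution pattern on the ring at once, so the compounds shown cannot say how much of the step belongs to chlorine in place of bromine and how much to the pattern; 3-chlorophenyl and 3,4-dibromophenyl on the same chain are the groups that would separate the two. Also open, as far as these compounds go, is whether the 3,4-dichlorophenyl group would have the same effect on a longer chain, or whether an unsubstituted phenyl group would sit above or below these numbers.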